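This account rests on a few compounds, and the source may have more. Where it says the series, first, only, none or still open, it means among the compounds named here.

Of the compounds shown here, three of a shared core have been tested in a functional assay on PC-3 cells (Homo sapiens) for inhibition, read by sulforhodamine B assay, with a stated time of 48 h, tested at 50 uM; a higher number here means more inhibition of growth at the concentration tested, a lower number less inhibition of growth. Compound 1 `COc1cc(/C=C/C(=O)/C=C/c2ccccc2)ccc1OCc1cn(CCCOc2cc(=O)oc3ccccc23)nn1` is reported in this assay as "not active" (no number reported), and compound 2 `COc1ccccc1/C=C/C(=O)/C=C/c1ccc(OCc2cn(CCCOc3cc(=O)oc4ccccc34)nn2)c(OC)c1` likewise as "not active" (no number reported); for neither of them is a number given. Compound 3 `COc1ccccc1/C=C/C(=O)/C=C/c1ccc(OCc2cn(CCOc3cc(=O)oc4ccccc34)nn2)c(OC)c1` is the only one of the three with a number, giving 11% in this assay, which places it at the low end of what this read-out can show, with no measured neighbour to set it against.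

Compound 4 `COc1cc(/C=C/C(=O)/C=C/c2cc(OC)c(OC)c(OC)c2)ccc1OCc1cn(CCOc2cc(=O)oc3ccccc23)nn1` has not yet been measured in this assay. It differs from compound 3 in one place: 3,4,5-trimethoxyphenyl in place of 2-methoxyphenyl on a double-bonded chain carbon bound to a double-bonded chain carbon. Within the data shown here, no step between two measured compounds describes such a change, so there is nothing in these data to say whether the new group raises or lowers growth inhibition. The expectation is therefore a small step, a number 7 percentage points higher from compound 3 to compound 4 (within the scatter), not clearly beyond the usual scatter in either direction. For compound 4 the estimated value in this assay is 18%, with a range from 0% to 45%.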

Compound 4, percent growth inhibition at one concentration: 22%
Estimate against measurement, compound 4: 4 percentage points below, and the stated range covers the measured number.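

With 3,4,5-trimethoxyphenyl in place of 2-methoxyphenyl on a double-bonded chain carbon bound to a double-bonded chain carbon, this assay gives a number 11 percentage points higher from compound 3 to compound 4 (beyond the scatter). Among these compounds, this is the first step that can be read as a number, and it shows that growth inhibition responds to the group at this position, though only modestly at the single concentration tested. Nothing at hand explains what lies behind the step.

Steps involving the compounds reported without a number cannot be read, so the effect of the chain joining the shared core to the triazole remains unknown. On these data alone, it also remains open whether a dimethylamino group or a carboxylic acid on this phenyl ring would raise growth inhibition further or lower it.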